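The source may hold more compounds than are shown below. What is called first, only, known or untested is meant among the compounds shown, and "the series" means these compounds.

Working notes on the series in an assay for inhibition of Amine oxidase [flavin-containing] A (Homo sapiens), read by fluorescence and spectrophotometry, using microsomes, with stated times of 30 min and 20 min; a lower number here means a stronger inhibitor, a higher number a weaker inhibitor. Compound 1 `Cc1nc(-c2ccc(C3=NCCN3)cc2)no1` gives 41100 nM in this assay. Compound 2 `CC1CN=C(c2ccc(-c3noc(-c4ccc(Cl)c(Cl)c4)n3)cc2)N1` gives 14700 nM in this assay. Compound 3 `c1ccc(OCc2noc(-c3ccc(C4=NCCN4)cc3)n2)cc1` returns only a limit in this assay, > 100000 nM. That limit is the point where the numbers stop, as marked by the limit of > 100000 nM in this assay, at which 1 of the 3 values shown sits, so compound 3 stands as the one member of the set without a read value; on the numbers shown it sits no closer than compound 1 or compound 2. Compound 4 `Clc1cccc(-c2noc(-c3ccc(C4=NCCN4)cc3)n2)c1` is the next member. The change from compound 3 to compound 4 is 3-chlorophenyl in place of phenoxymethyl on an aromatic carbon of the shared core. Going by the values given here, no measured pair differs in one place, so the step from compound 3 to compound 4 has no direct precedent. Compound 1 and compound 2, both with a group bound directly to that carbon, give numbers rather than limits, so compound 4 is expected to move from the limit toward a measurable value. The step from compound 3 to compound 4 is expected at an at least 3.3-fold lower number from compound 3 to compound 4 (0.52 log units; beyond the scatter), a gain beyond the scatter. Compound 4 is estimated at 30000 nM, within 8000 nM to 120000 nM.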

Compound 4, half-maximal inhibitory concentration: 5470 nM
Compound 4: middle estimate off by 5.5-fold (0.74 log units), on the high side, and the stated range ends above it.
By their numbers in this assay, from the lowest: compound 4; then compound 2; then compound 1. At a limit, above all of these: compound 3.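

In this assay, the exchange of phenoxymethyl for 3-chlorophenyl on this aromatic carbon gives an at least 18-fold lower number from compound 3 to compound 4 (1.26 log units; beyond the scatter), the first direct sign that the series responds strongly to the group at this position. The size of this step is only a bound, since compound 3 gives a limit and not a read number: the limit of > 100000 nM in this assay, at which 1 of the 4 values shown sits. The exchange also changes two things at once, removing the phenoxymethyl link and bringing in a chlorine on the ring, and this single step does not separate them.

On these data alone, how an unsubstituted phenyl would read at this carbon remains open, and that comparison would show how much of the step belongs to the chlorine. Also open, as far as these compounds go, is how an amine or a carboxylic acid on that ring would read in this assay.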